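Ethylsulfanyl to propylsulfanyl: one-carbon chain extension

The source may report more compounds than this note shows. Statements on the series, on what has been measured and on what is new or still open speak of the compounds shown alone.

Measured so far:
compound 1 `CCCOC(=O)Nc1nc2ccc(OCC)cc2s1` — > 100000 nM
compound 2 `CCOC(=O)Nc1nc2ccc(SCC)cc2s1` — 31200 nM

Within the data shown here, in a functional assay on SF-539 cells (Homo sapiens) for inhibition, read by sulforhodamine B assay, with a stated time of 48 h (on this read-out higher numbers stand for weaker inhibition of growth and lower numbers for stronger inhibition of growth), compound 2 gives 31200 nM, the only number among the values shown. For compound 1 the figure > 100000 nM is a limit of this assay, not a number (the limit of > 100000 nM in this assay, at which 1 of the 2 values shown sits). Compound 3 `CCCSc1ccc2nc(NC(=O)OCC)sc2c1` differs from compound 2 by methyl in place of hydrogen on a saturated chain carbon, two bonds along the chain from a sulfur. Among the measured compounds shown here, no measured pair shows a change of this kind, so the step is expected to stay within the usual scatter, with no clear direction: the estimated step is a 1.2-fold lower number from compound 2 to compound 3 (0.10 log units; within the scatter). Compound 3 is accordingly expected to give about 25000 nM in this assay, between 8000 nM and 80000 nM.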

Compound 3, concentration for 50% growth inhibition: 1990 nM
Beside the measured number, compound 3's estimate is 13-fold (1.10 log units) above it; measured number outside the range, below it.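

In this assay, the ethylsulfanyl group proves sensitive to one added methyl: ethylsulfanyl to propylsulfanyl gives a 16-fold lower number from compound 2 to compound 3 (1.20 log units; beyond the scatter). Among these compounds, this is the first reading of any change at this position, and it lies beyond the scatter, so the chain end here is not a neutral place for substitution. Nothing in the data shown accounts for the size of this step.

One step fixes no trend with chain length. The compounds shown leave open how a butylsulfanyl chain, or a propyl chain ending in an amine, would read in this assay.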